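The source may report more compounds than this note shows. Statements on the series, on what has been measured and on what is new or still open speak of the compounds shown alone.

Measured so far in an ADME assay on microsomes from liver (Rattus norvegicus) for metabolic stability; on this read-out higher numbers stand for fast clearance and lower numbers for slow clearance:
Compound 1 `Cc1cnc(-c2cc(Oc3ccc(S(C)(=O)=O)cc3)cc(OC(C)C)c2)[nH]c1=O` gives 189 mL/min/kg here.
Compound 2 `COc1cnc(-c2cc(Oc3ccc(S(C)(=O)=O)cc3)cc(OC(C)C)c2)[nH]c1=O` gives < 25.4 mL/min/kg as a limit of the assay.

Going by the values given here, compound 2 thus stands only at a limit, with no exact number to step from. Compound 3 `CC(C)Oc1cc(Oc2ccc(S(C)(=O)=O)cc2)cc(-c2ncc(Cl)c(=O)[nH]2)c1` carries chloro in place of methoxy on an aromatic carbon. Among the compounds with values here, the one measured step on that carbon is an at least 7.4-fold lower number from compound 1 to compound 2 (0.87 log units; beyond the scatter) (methoxy in place of methyl) and it lies beyond the scatter. Chloro has no measured precedent in the series, so the low number of compound 2 is not expected to carry over in full. The expected move is an at least 2.3-fold higher number from compound 2 to compound 3 (0.37 log units; beyond the scatter) (upward, and smaller than the measured step). For compound 3 the estimated clearance is 60 mL/min/kg (expected range 25 mL/min/kg to 140 mL/min/kg).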

Compound 3, clearance: < 25.4 mL/min/kg
Compound 3 gave a limit, no number; the forecaster's own chance of this, stated with the estimate: 25%; middle value at least 2.3-fold (0.37 log units) away from the limit.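

In this assay, chloro in place of methyl gives an at least 7.4-fold lower number from compound 1 to compound 3 (0.87 log units; beyond the scatter), so on this aromatic carbon the drop from compound 1 is not confined to methoxy. Compound 3 stands at a limit of the assay, not at a number. The two limits leave the step between compound 2 and compound 3 unreadable, so methoxy and chloro cannot be ranked here: the limit of < 25.4 mL/min/kg in this assay, at which 2 of the 3 values shown sit.

Still open, as far as these compounds go, is how much lower the true values of compound 2 and compound 3 lie. Also open, from the compounds shown here alone, is whether an amine or a nitrile on this carbon would give a similarly large step from compound 1.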